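The source may hold more compounds than are shown below. What is called first, only, known or untested is meant among the compounds shown, and "the series" means these compounds.

Compound 2 `CCCCCCCCCCc1ccc(-c2noc(-c3cccc(CN)c3)n2)cc1` has, on the numbers shown, the lower of the two measured values: in an assay on HeLa cells for inhibition of sphingosine-1-phosphate transporter SPNS2 (Mus musculus), read by LC-MS, tested at 2 uM (on this read-out higher numbers stand for more inhibition at the one concentration tested (going by the name of the read-out) and lower numbers for less inhibition), compound 2 gives 2%, the lowest of the two values, while compound 1 `CCCCCCCCCCc1ccc(-c2noc([C@@H]3CCNC3)n2)cc1` gives 62% in this assay. For the measured compounds named here, the one measured step between them, a number 60 percentage points lower from compound 1 to compound 2 (beyond the scatter), is the only guide available. Compound 3 `CCCCCCCCCCc1ccc(-c2noc([C@@H](N)CCCN)n2)cc1` has not yet been measured. It differs from compound 2 in one place: 1,4-diaminobutyl in place of 3-(aminomethyl)phenyl on an aromatic carbon. The step from compound 1 to compound 2 bears on this change, since compound 3 again carries a group with a stereocentre on the same aromatic carbon of the shared core, as compound 1 does, while the 3-(aminomethyl)phenyl of compound 2 leaves. That step was large, and the account therefore expects a step of similar size in this assay but in the opposite direction, from compound 2 to compound 3, estimated as a number 43 percentage points higher from compound 2 to compound 3 (beyond the scatter). For compound 3 the estimate in this assay is 45%, with a range from 15% to 75%.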

Compound 3, a percentage reported as inhibition, at one concentration (the size of the read-out at that concentration, not a potency): 40%
For compound 3 the middle estimate is 5 percentage points above the measured one; the measured number falls inside the stated range.
By their numbers in this assay, from the lowest: compound 2; then compound 3; then compound 1.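

On the aromatic carbon of the five-membered ring, the result in this assay shows that an open chain can restore much of the inhibition lost with the 3-(aminomethyl)phenyl group: the change to 1,4-diaminobutyl gives a number 38 percentage points higher from compound 2 to compound 3 (beyond the scatter) and so a ring in this group is not needed for clear inhibition at the concentration tested. The same chain does not fully match the pyrrolidin-3-yl group, as replacing that ring with 1,4-diaminobutyl gives a number 22 percentage points lower from compound 1 to compound 3 (beyond the scatter) and this modest loss places the open chain between the two ring-bearing groups in this series of three. No measurement here explains either step, so the reason for this order remains unknown.

The compounds shown leave open which of the two amines in 1,4-diaminobutyl matters more, a question that a butyl chain carrying a single amine could address, and whether the opposite configuration at its stereocentre would give the same inhibition. They also leave open whether the low value of compound 2 belongs to its aromatic ring, which a saturated cyclohexyl ring bearing the same aminomethyl group could test.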